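Aryl swap on the shared core: compound 3 to compound 4

The compounds below may be only part of what the source reports. "The series", "measured", "known", "first", "only" and "open" are said of these compounds alone.

In a functional assay on MCF-A cells (Homo sapiens) for cytotoxicity (a lower number here means a stronger inhibitor of growth, a higher number a weaker inhibitor of growth), compound 1 `COc1ccc(C2=C(c3cc(OC)c(OC)c(OC)c3)CC3CCCN3C2=O)cc1O` gives only a limit, > 100000 nM.
In this assay compound 2 `COc1ccc(C2=C(c3ccc(SC)cc3)CC3CCCN3C2=O)cc1OC(=O)CNC(=O)OC(C)(C)C` gives 6000 nM.
In this assay compound 3 `COc1ccc(C2=C(c3ccc(SC)cc3)CC3CCCN3C2=O)cc1Br` gives 6000 nM.

Among the compounds with values here, compound 3 stands level with compound 2, the only measured step being no change at the digits printed from compound 2 to compound 3 (within the scatter). Compound 1 differs from both in more than one place, and its value is a limit (the limit of > 100000 nM in this assay, at which 1 of the 3 values shown sits).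

Compound 4 `CSc1ccc(C2=C(c3ccc(F)c(F)c3)C(=O)N3CCCC3C2)cc1` differs from compound 3 by 3,4-difluorophenyl in place of 3-bromo-4-methoxyphenyl on a double-bonded ring carbon. Within the data shown here, no measured step touches this position; the single step of no change at the digits printed from compound 2 to compound 3 (within the scatter) concerns another part of the molecule and offers no guidance. With nothing pointing either way, the growth inhibition of compound 4 is expected to stay near that of compound 3, with a 1.3-fold higher number from compound 3 to compound 4 (0.12 log units; within the scatter) as the expected step; the estimate for compound 4 is 8000 nM, between 2500 nM and 30000 nM.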

Compound 4, concentration for 50% growth inhibition: 800 nM
Compound 4: the middle estimate sits 10-fold (1.00 log units) above what was measured, outside the stated range (below it).
By their numbers in this assay, from the lowest: compound 4; then compounds 2 and 3 (each within the scatter of the next). At a limit, above all of these: compound 1.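

In this assay the aryl group on the double-bonded ring carbon affects growth inhibition, giving a 7.5-fold lower number from compound 3 to compound 4 (0.88 log units; beyond the scatter) on this single exchange. The exchange replaces 3-bromo-4-methoxyphenyl with 3,4-difluorophenyl as a whole, so the share of the bromine, the methoxy group and each fluorine cannot be separated. Nothing measured here accounts for the step.

On these data alone, whether a single fluorine alone would hold the lower number remains open. So does the effect of an amine or a carboxylic acid on this phenyl ring.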